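From a Bare Ring Carbon to Thiophen-2-yl

The compounds below may be only part of what the source reports. "The series", "measured", "known", "first", "only" and "open" are said of these compounds alone.

Of the compounds shown here, three have been measured in an ADME assay on S9 fraction from liver (Rattus norvegicus) for metabolic stability, read by LC-MS, using NADPH, with a stated time of 30 min; a higher number here means that more of the compound is left, a lower number that less of the compound is left. Compound 1 `CCCCCCCCc1ccc(OCC(=O)Cn2cnnn2)cc1` gives 22%, the lowest of the two numbers, while compound 2 `CCCCCCCCc1ccc(OCC(=O)Cn2nnc(-c3ccc(C(=O)OC)cc3)n2)cc1` gives 64%, which lies beyond the scatter above it. Compound 3 `CCCCCCCCc1ccc(OCC(=O)Cn2nnc(-c3cccc(C(=O)O)c3)n2)cc1` gives < 5%, a limit of the assay rather than a number. Within the data shown here, the only measured step, a number at least 59 percentage points lower from compound 2 to compound 3 (beyond the scatter), swaps 4-(methoxycarbonyl)phenyl for 3-carboxyphenyl on the attached aryl group, so it bears only loosely on the change at hand. Compound 4 `CCCCCCCCc1ccc(OCC(=O)Cn2nnnc2-c2cccs2)cc1` differs from compound 1 by thiophen-2-yl in place of hydrogen on an aromatic carbon. Among the measured compounds shown here, the values of compound 1 and compound 2 show that a ring group on this aromatic carbon can go with more compound remaining, though no step links them. The expected step is a number 16 percentage points higher from compound 1 to compound 4 (beyond the scatter), a modest rise. Compound 4 is estimated at 38%, within 12% to 65%.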

Compound 4, percent of the compound remaining: 27%
Beside the measured number, compound 4's estimate is 11 percentage points above it, within the range that was stated.
By their numbers in this assay, from the lowest: compounds 1 and 4 (each within the scatter of the next); then compound 2. At a limit, below all of these: compound 3.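

Placing thiophen-2-yl in place of hydrogen on this aromatic carbon gives a number 5 percentage points higher from compound 1 to compound 4 (within the scatter), so this assay does not separate the two compounds. Among these compounds, this is the direct reading at this position that the earlier compounds lacked: a five-membered aromatic ring with 1 hetero atom can sit here with no change beyond the scatter. Nothing measured here accounts for this result.

On these data alone, what remains open is how an amine, a carboxylic acid or a longer alkyl chain on this same carbon would compare with hydrogen.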